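A few compounds are considered here, and "the series" means these few. Any claim that something is new, unique, unknown or untested is made for them only; others in the source may bear on it.

Measured compounds:
Compound 1, `COc1cccc2[nH]cc(C3(c4c[nH]c5cccc(OC)c45)C(=O)Nc4ccccc43)c12`: 14100 nM
Compound 2, `O=C1Nc2ccccc2C1(c1c[nH]c2ccc(Br)cc12)c1c[nH]c2ccc(Br)cc12`: 46800 nM

In a functional assay on MCF7 cells (Homo sapiens) for cytotoxicity, read by MTT assay, with a stated time of 48 h (on this read-out higher numbers stand for weaker inhibition and lower numbers for stronger inhibition), compound 1 gives 14100 nM, the lowest of the two numbers shown. In this assay compound 2 gives 46800 nM, a higher number, so compound 1 is the stronger inhibitor of the two, and that gap lies beyond the usual scatter of repeated measurements. Compound 3, `COc1cccc2[nH]cc(C3(c4c[nH]c5cccc(OC)c45)C(=O)Nc4ccc(F)cc43)c12`, has not yet been measured. It differs from compound 1 in one place: fluoro in place of hydrogen on an aromatic carbon. Within the data shown here, no pair of measured compounds isolates a change of this kind, so there is no measured basis for a large shift either way. The expected step is therefore small, a 1.4-fold lower number from compound 1 to compound 3 (0.15 log units; within the scatter), if anything toward a slightly lower number and quite possibly within the scatter. On that basis compound 3 is estimated at 10000 nM, with a range from 3000 nM to 35000 nM.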

Compound 3, half-maximal inhibitory concentration: 7500 nM
Estimate against measurement, compound 3: 1.3-fold (0.12 log units) above; the measured number falls inside the stated range.
By their numbers in this assay, from the lowest: compounds 3 and 1 (each within the scatter of the next); then compound 2.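

In this assay, among these compounds, the swap of fluoro in place of hydrogen on an aromatic carbon gives a 1.9-fold lower number from compound 1 to compound 3 (0.27 log units; within the scatter) and is the first single change that can be read. Compound 1 and compound 3 cannot be told apart on this read-out, so this position on the shared core accepts a fluoro without a clear loss of activity, and no real gain can be claimed either. No measurement is at hand that would explain the size of this step. Going by these compounds, whether a larger group at this same carbon, such as a methoxy, an amine or a trifluoromethyl, would move the number beyond the scatter remains open. Also open, on these data alone, is whether fluoro would act the same way on the other carbons of this ring.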